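Lengthening the benzyl chain on a nitro-indole carboxylic acid

A few compounds are considered here, and "the series" means these few. Any claim that something is new, unique, unknown or untested is made for them only; others in the source may bear on it.

Measured compounds:
compound 1 `O=C(O)c1ccc(Cn2c(C(=O)O)cc3cc(S(=O)(=O)N(Cc4ccccc4)Cc4ccccc4)ccc32)cc1`: 250 nM
compound 2 `O=C(O)c1cn(Cc2ccccc2)c2ccc([N+](=O)[O-])cc12`: 27500 nM

In an assay on cells (Oocyte) for inhibition of pannexin-1 (Mus musculus), read by voltage clamp, in the presence of a further agent that is not named here (a higher number here means a weaker inhibitor, a lower number a stronger inhibitor), compound 1 gives 250 nM and compound 2 gives 27500 nM. Compound 2 therefore has the highest number of the two, and its gap to compound 1, the nearest neighbour, lies well beyond the scatter. Compound 3 `O=C(O)c1cn(CCCc2ccccc2)c2ccc([N+](=O)[O-])cc12` differs from compound 2 by phenethyl in place of phenyl on a saturated chain carbon bound to an aromatic nitrogen. Among the measured compounds shown here, no measured pair shows this change, so no step can be read off. The step of a 1.1-fold lower number from compound 2 to compound 3 (0.04 log units; within the scatter) is expected to stay within the scatter, in no clear direction. Compound 3 is estimated at 25000 nM in this assay, between 8000 nM and 80000 nM.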

Compound 3, half-maximal inhibitory concentration: 12400 nM
The estimate for compound 3 lay 2.0-fold (0.30 log units) above the measured number; the measured number falls inside the stated range.
By their numbers in this assay, from the lowest: compound 1; then compound 3; then compound 2.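

In this assay, phenethyl in place of phenyl on a saturated chain carbon bound to an aromatic nitrogen gives a 2.2-fold lower number from compound 2 to compound 3 (0.35 log units; beyond the scatter). Among the compounds shown here, this is the first evidence on this position: the longer group is tolerated, and the number falls modestly rather than rising. Nothing shown accounts for the shift.

As far as these compounds go, whether a longer chain or an amine in place of phenethyl would lower the number further remains open. So does whether the same change would have a similar effect on the core of compound 1.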